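This account rests on a few compounds, and the source may have more. Where it says the series, first, only, none or still open, it means among the compounds named here.

The measured compounds:
Compound 1 `CCNCc1cc(Cl)cc(Nc2nc3ccccc3n2Cc2ccc(C(F)(F)F)cc2)c1O`: 12000 nM
Compound 2 `CCNCc1cc(Cl)cc(Nc2nc3cc(F)c(F)cc3[nH]2)c1O`: 12000 nM
Compound 3 `CCNCc1cc(Cl)cc(Nc2nc3cc(F)c(F)cc3n2Cc2ccc(C(F)(F)F)cc2)c1O`: a limit of the assay, < 5000 nM

All three were read in a physicochemical assay for solubility, read by HPLC, measured as kinetic solubility, with a stated time of 24 h, at pH 6.5; on this read-out higher numbers stand for higher solubility and lower numbers for lower solubility. In this assay compound 1 and compound 2 stand level at the digits given. For compound 3 the assay reports only a limit, (the limit of < 5000 nM in this assay, at which 1 of the 3 values shown sits). How the core of compound 1 differs from that of compound 3 is not broken down here.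

Compound 4 `CCNCc1cc(Cl)cc(Nc2nc3ccccc3[nH]2)c1O` has not yet been measured in this assay. It arises from compound 1 by the same change that turns compound 3 into compound 2: hydrogen in place of 4-(trifluoromethyl)benzyl on an aromatic nitrogen, just as hydrogen in place of 4-(trifluoromethyl)benzyl on an aromatic nitrogen. Where that change was measured it gave an at least 2.4-fold higher number from compound 3 to compound 2 (0.38 log units; beyond the scatter), the full size left open by the limit on compound 3.

The expected step is a 2.1-fold higher number from compound 1 to compound 4 (0.32 log units; beyond the scatter), resting on an at least 2.4-fold higher number from compound 3 to compound 2 (0.38 log units; beyond the scatter). The starting point is compound 1 at 12000 nM, already level with compound 2. Compound 4 is estimated at 25000 nM, within 10000 nM to 70000 nM.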

Compound 4, solubility: 200000 nM
Compound 4: the middle estimate sits 8.0-fold (0.90 log units) below what was measured; the whole stated range lies below it.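

In this assay, hydrogen in place of 4-(trifluoromethyl)benzyl on an aromatic nitrogen gives a 17-fold higher number from compound 1 to compound 4 (1.22 log units; beyond the scatter), and the same change on the other core gives an at least 2.4-fold higher number from compound 3 to compound 2 (0.38 log units; beyond the scatter). The direction of the change therefore carried over between the two cores shown, though two cores are too few to establish a rule for the series. What this does not show is whether the size carried over, since the two steps cannot be set against each other because the step on the core of compound 3 has no fixed size: the limit of < 5000 nM in this assay, at which 1 of the 4 values shown sits.

The compounds shown leave open how other groups on that aromatic nitrogen, such as methyl, unsubstituted benzyl or a chain ending in a carboxylic acid, would read in this assay. They also leave open whether the step would keep its direction on a core carrying a nitrile or a methoxy group.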